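Replacing methoxycarbonyl with 2-carboxyethenyl

The compounds below may be only part of what the source reports. "The series", "measured", "known", "first", "only" and "open" are said of these compounds alone.

In a functional assay on CLL cells (Homo sapiens) for cytotoxicity, read by MTT assay, with a stated time of 48 h (on this read-out higher numbers stand for an effect only at larger amounts of compound and lower numbers for an effect already at smaller amounts), compound 1 `C=C(CC)C(=O)c1ccc(OCC(=O)Nc2ccc(/C=C/C(=O)NO)cc2)c(Cl)c1Cl` gives 2600 nM and compound 2 `C=C(CC)C(=O)c1ccc(OCC(=O)Nc2ccc(C(=O)OC)cc2)c(Cl)c1Cl` gives 4100 nM. For the measured compounds named here, these are the only two measurements so far, and they lie within the usual scatter of each other, so compound 2 cannot be ranked apart from compound 1.

Compound 3 `C=C(CC)C(=O)c1ccc(OCC(=O)Nc2ccc(/C=C/C(=O)O)cc2)c(Cl)c1Cl` keeps the rest of compound 2 and changes one group, with 2-carboxyethenyl in place of methoxycarbonyl on an aromatic carbon.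

Going by the values given here, one measured step bears on this change. It also exchanged methoxycarbonyl with another group on an aromatic carbon, in that case 2-(hydroxycarbamoyl)ethenyl, and it amounted to a 1.6-fold higher number from compound 1 to compound 2 (0.20 log units; within the scatter). Among the compounds with values here, a single small step is thin evidence, and no measured compound yet carries the 2-carboxyethenyl group. The expectation in this assay is therefore no step beyond the scatter, in either direction. The step expected is a 1.0-fold lower number from compound 2 to compound 3 (0.01 log units; within the scatter). For compound 3 the estimated value is 4000 nM, with an expected range from 1600 nM to 10000 nM.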

Compound 3, half-maximal effective concentration: 3000 nM
Compound 3: middle estimate off by 1.3-fold (0.12 log units), on the high side, and the stated range covers the measured number.
By their numbers in this assay, from the lowest: compounds 1, 3 and 2 (each within the scatter of the next).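

In this assay, for the compounds shown here, putting 2-carboxyethenyl in place of methoxycarbonyl on this aromatic carbon, para to a large group, gives a 1.4-fold lower number from compound 2 to compound 3 (0.14 log units; within the scatter) as its result, so the first direct reading of this change shows no difference that can be told from the scatter, even though the entering group carries a hydrogen-bond donor and the leaving group carries none. The new comparison with the hydroxamic acid end of compound 1, hydroxy in place of hydroxyamino on a carbonyl carbon, amounts to a 1.2-fold higher number from compound 1 to compound 3 (0.06 log units; within the scatter) as its step, so all three groups now seen at this position lie within the scatter of one another, and this single cell assay does not separate them. Nothing available explains why these three groups read so alike in this assay.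

On these data alone, what remains open is whether any group at this position can move the number beyond the scatter, for example a simple amine on the aromatic carbon or a longer chain carrying the carboxylic acid. It is also open whether this flat picture would hold if the shared core of these compounds were changed elsewhere.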